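Swapping Chloromethyl for Trifluoromethyl on a Shared Core

The compounds below may be only part of what the source reports. "The series", "measured", "known", "first", "only" and "open" are said of these compounds alone.

Compound 1 `O=C(O)c1cc(N2C(=O)CSC2=S)ccc1Cl` gives 155000 nM.
Compound 2 `COC(=O)c1ccc(-c2noc(CCl)n2)cc1` gives 14200 nM.
Compound 3 `O=C(O)c1ccc(-c2noc(CCl)n2)cc1` gives 64000 nM.

These three compounds were tested in an ADME assay on MT2 cells (Homo sapiens) for cytotoxicity, read by XTT assay, with a stated time of 4 days; a lower number here means that less compound is tolerated, a higher number that more compound is tolerated. Among the measured numbers compound 3 stands second highest of three: compound 1 sits one step beyond the scatter above it, and compound 2 a larger step below it. Among the measured compounds shown here, the single measured step between neighbours, a 4.5-fold higher number from compound 2 to compound 3 (0.65 log units; beyond the scatter), concerns hydrogen in place of methyl on an oxygen next to a carbonyl group, not the five-membered aromatic ring.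

Compound 4 `O=C(O)c1ccc(-c2noc(C(F)(F)F)n2)cc1` has not yet been measured in this assay. It differs from compound 3 in one place: trifluoromethyl in place of chloromethyl on an aromatic carbon. For the measured compounds named here, no measured step in this set touches that aromatic carbon, so there is no direct precedent. Going by the values given here, the step of a 4.5-fold higher number from compound 2 to compound 3 (0.65 log units; beyond the scatter) shows only that a single-group change elsewhere on the shared core moved the number by a modest amount beyond the scatter. A step of similar or smaller size is therefore expected here, its direction uncertain, and a 1.6-fold higher number from compound 3 to compound 4 (0.19 log units; within the scatter) is the step the estimate assumes. For compound 4 the expected value is 100000 nM, within a range from 40000 nM to 300000 nM.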

Compound 4, half-maximal cytotoxic concentration: 82300 nM
The estimate for compound 4 lay 1.2-fold (0.08 log units) above the measured number, within the range that was stated.
By their numbers in this assay, from the lowest: compound 2; then compounds 3, 4 and 1 (each within the scatter of the next, the first and the last beyond it).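

In this assay, among the compounds shown here, the first change at this aromatic carbon, trifluoromethyl in place of chloromethyl, gives a small result (a 1.3-fold higher number from compound 3 to compound 4 (0.11 log units; within the scatter)), and this step stays within the usual scatter. For the compounds shown here, the only earlier step changed a different part of the shared core, hydrogen in place of methyl on an oxygen next to a carbonyl group (a 4.5-fold higher number from compound 2 to compound 3 (0.65 log units; beyond the scatter)), and it said nothing about this position. Here, a chloromethyl group of 2 heavy atoms and a trifluoromethyl group of 4 heavy atoms cannot be told apart by this read-out, although no measurement offers a reason for that.

Going by these compounds, it remains open whether a quite different group on this aromatic carbon, such as an amine or a longer chain, would also leave the number within the scatter of compound 3, or would move it clearly. On these data alone, it is also open whether the same swap would behave alike on the methyl ester of compound 2, while compound 1 differs from these compounds in more than one place and offers no guide.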